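Lengthening the chain from compound 3 to compound 4

The source may report more compounds than this note shows. Statements on the series, on what has been measured and on what is new or still open speak of the compounds shown alone.

Compound 1 `CCN(CC)CCCCn1c(N)c(-c2nc3ccccc3n2C)c2nc(C#N)c(C#N)nc21`: 2890 nM
Compound 2 `CCN(CC)CCn1c(N)c(-c2nc3cc(Cl)ccc3[nH]2)c2nc(C#N)c(C#N)nc21`: > 50000 nM (a limit of the assay, not a number)
Compound 3 `CCN(CC)CCCn1c(N)c(-c2nc3cc(Cl)ccc3[nH]2)c2nc(C#N)c(C#N)nc21`: 23200 nM

In a functional assay on cells (Homo sapiens) for antiproliferative activity, read by MTT assay, with a stated time of 48 h (on this read-out higher numbers stand for weaker inhibition and lower numbers for stronger inhibition), compound 3 at 23200 nM holds the higher of the two numerical values. Compound 1 gives 2890 nM, and that gap lies beyond the scatter. Compound 2 gives > 50000 nM, which is a limit and not a number.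

Compound 4 `CCN(CC)CCCCn1c(N)c(-c2nc3cc(Cl)ccc3[nH]2)c2nc(C#N)c(C#N)nc21` has not yet been measured. Compared with compound 3 it has (diethylamino)methyl in place of diethylamino on a saturated chain carbon, three bonds along the chain from an aromatic nitrogen. This turns 3-(diethylamino)propyl into 4-(diethylamino)butyl.

The same kind of change, made one bond closer to the aromatic nitrogen, gave an at least 2.1-fold lower number from compound 2 to compound 3 (0.33 log units; beyond the scatter). One end of that step is a limit, so it sets only a bound on the size, and it is a single example. Compound 1 also carries the 4-(diethylamino)butyl chain and gives 2890 nM, but it differs from compound 4 elsewhere and is only a loose guide.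

A modest further drop is therefore expected, estimated as a 2.3-fold lower number from compound 3 to compound 4 (0.37 log units; beyond the scatter). For compound 4 the estimated value in this assay is 10000 nM, with an expected range from 3500 nM to 30000 nM.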

Compound 4, half-maximal inhibitory concentration: 2840 nM
Compound 4: middle estimate off by 3.5-fold (0.55 log units), on the high side; the whole stated range lies above it.
By their numbers in this assay, from the lowest: compounds 4 and 1 (each within the scatter of the next); then compound 3. At a limit, above all of these: compound 2.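

In this assay, among these compounds, going from 3-(diethylamino)propyl to 4-(diethylamino)butyl at this position gives an 8.2-fold lower number from compound 3 to compound 4 (0.91 log units; beyond the scatter), which shows that the gain from lengthening the chain did not stop at the propyl stage, something the earlier compounds could not show. Across the three chains carrying 5-chloro-1H-benzimidazol-2-yl, the whole change amounts to an at least 17-fold lower number from compound 2 to compound 4 (1.24 log units; beyond the scatter), and this size is only a bound because the value of compound 2 is a limit and not a number: the limit of > 50000 nM in this assay, at which 1 of the 4 values shown sits. With the 4-(diethylamino)butyl chain held fixed, 5-chloro-1H-benzimidazol-2-yl in place of 1-methyl-1H-benzimidazol-2-yl gives a 1.0-fold lower number from compound 1 to compound 4 (0.01 log units; within the scatter), so the two groups cannot be told apart on this chain in this assay.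

The compounds shown do not tell whether a longer chain, such as 5-(diethylamino)pentyl, would extend this trend or end it, or whether a ring amine such as piperidine or morpholine could stand in for diethylamino. Nor do they show whether chain length works the same way with 1-methyl-1H-benzimidazol-2-yl, which appears here only on the 4-(diethylamino)butyl chain.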